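This account rests on a few compounds, and the source may have more. Where it says the series, first, only, none or still open, it means among the compounds named here.

Measured in a functional assay on DU-145 cells (Homo sapiens) for cytotoxicity, read by MTT assay; a higher number here means a weaker inhibitor, a lower number a stronger inhibitor:
- Compound 1 `CCCCC(O)CC(=O)O[C@H](CC=C(C)C)C1=CC(=O)c2c(O)ccc(O)c2C1=O`: 45300 nM
- Compound 2 `CC(C)=CC[C@@H](OC(=O)C1CCCO1)C1=CC(=O)c2c(O)ccc(O)c2C1=O`: 10500 nM

Of these two, compound 2 has the lower number, at 10500 nM, and so is the stronger inhibitor in this assay. The next compound, compound 3 `CC(C)=CC[C@@H](OCCO)C1=CC(=O)c2c(O)ccc(O)c2C1=O`, departs from compound 2 at one place: 2-hydroxyethyl in place of (oxolan-2-yl)carbonyl on an oxygen on a saturated carbon. Here 2-hydroxyethyl stands in place of (oxolan-2-yl)carbonyl on an oxygen on a saturated carbon.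

Within the data shown here, only one measured step bears on this change: a 4.3-fold lower number from compound 1 to compound 2 (0.63 log units; beyond the scatter). That modest step, beyond the scatter, exchanged groups on a carbonyl carbon, whereas here the carbonyl itself leaves, so it offers only a rough guide to size and none to direction. Among the measured compounds shown here, no measured compound lacks that carbonyl. A shift beyond the scatter is therefore not expected in either direction. The estimated change is a 1.2-fold lower number from compound 2 to compound 3 (0.07 log units; within the scatter). Compound 3 is expected at 9000 nM, with an estimated range of 3000 nM to 30000 nM.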

Compound 3, half-maximal inhibitory concentration: 9900 nM
The estimate for compound 3 lay 1.1-fold (0.04 log units) below the measured number; the measured number falls inside the stated range.
By their numbers in this assay, from the lowest: compounds 3 and 2 (each within the scatter of the next); then compound 1.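

Removing the carbonyl and the five-membered ring together leaves the number in this assay essentially where it was, with a 1.1-fold lower number from compound 2 to compound 3 (0.03 log units; within the scatter) as the step. On this oxygen, then, neither the carbonyl nor the ring is needed to hold this level of cytotoxicity, and 2-hydroxyethyl serves as well as (oxolan-2-yl)carbonyl. Among these compounds, compound 1 now stands apart from both other compounds, with a 4.6-fold lower number from compound 1 to compound 3 (0.66 log units; beyond the scatter) as its step to the 2-hydroxyethyl compound, so (2-hydroxyhexyl)carbonyl is the one group of the three that goes with the higher number.

Nothing at hand explains these numbers. As far as these compounds go, it remains open whether an amine or a carboxylic acid at the end of this chain, or a longer chain ending in hydroxyl, would keep the number or move it.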